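Methyl added to the chlorophenyl ring of compound 1

The source may hold more compounds than are shown below. What is called first, only, known or untested is meant among the compounds shown, and "the series" means these compounds.

Compound 1 `CC/C(=C(/c1ccc(/C=C/C(=O)O)cc1)c1cc2ccccc2[nH]1)c1ccccc1Cl` holds the second highest of three numbers in a functional assay on MCF7 cells (Homo sapiens) for inhibition; a lower number here means a stronger inhibitor, a higher number a weaker inhibitor: compound 1 gives 42 nM, compound 3 `CC/C(=C(/c1ccc(/C=C/C(=O)O)cc1)c1cc2ccccc2[nH]1)c1cccc(F)c1C#N` gives 40 nM, and compound 2 `CC/C(=C(/c1ccc(/C=C/C(=O)O)cc1)c1cc2ccccc2[nH]1)c1cccc(Cl)c1Cl` gives 898 nM. The step of a 1.1-fold lower number from compound 1 to compound 3 (0.02 log units; within the scatter) stays within the scatter, whereas a 21-fold higher number from compound 1 to compound 2 (1.33 log units; beyond the scatter) is large. Compound 4 `CC/C(=C(/c1ccc(/C=C/C(=O)O)cc1)c1cc2ccccc2[nH]1)c1c(C)cccc1Cl` differs from compound 1 by methyl in place of hydrogen on an aromatic carbon, the group entering on an aromatic carbon of the six-membered ring of carbon only, ortho to a large group and meta to the chloro group. For the measured compounds named here, the only measured step that adds a group to this ring, a 21-fold higher number from compound 1 to compound 2 (1.33 log units; beyond the scatter), cost much; no measured step adds a methyl. The expected step is therefore a 2.9-fold higher number from compound 1 to compound 4 (0.46 log units; beyond the scatter), a moderate loss with wide uncertainty. Compound 4 is estimated at 120 nM in this assay, between 40 nM and 400 nM.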

Compound 4, half-maximal inhibitory concentration: 30 nM
Compound 4: the middle estimate sits 4.0-fold (0.60 log units) above what was measured; measured number below the stated range.
By their numbers in this assay, from the lowest: compounds 4, 3 and 1 (each within the scatter of the next); then compound 2.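

In this assay, a methyl on this aromatic carbon, ortho to a large group and meta to the chloro group, costs nothing measurable: a 1.4-fold lower number from compound 1 to compound 4 (0.15 log units; within the scatter) shows that this ring can carry a second group here. The 2-chloro-6-methylphenyl ring also matches the 2-cyano-3-fluorophenyl ring, with a 1.3-fold lower number from compound 3 to compound 4 (0.12 log units; within the scatter), whereas a 30-fold lower number from compound 2 to compound 4 (1.48 log units; beyond the scatter) leaves compound 2 alone among these rings as the outlier. Nothing on hand explains this difference.

Open, going by these compounds, is whether a methoxy, an ethyl or an amine on this same carbon would fare as methyl does. Also open, on these data alone, is whether any larger group here would bring the large loss seen for compound 2.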